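The source may report more compounds than this note shows. Statements on the series, on what has been measured and on what is new or still open speak of the compounds shown alone.

Working notes on the series

Of the compounds shown here, three sharing one core have been measured in a functional assay on Ehrlich cells (Mus musculus) for cytotoxicity, read by trypan blue exclusion, with a stated time of 48 h; a higher number here means a weaker inhibitor, a lower number a stronger inhibitor. Compound 1 `Cc1ccc(-c2csc(NC(=O)COc3ccccc3C)n2)cc1` gives 54900 nM. Compound 2 `Cc1ccccc1OCC(=O)Nc1nc(-c2ccc(Cl)cc2)cs1` gives 63100 nM. Compound 3 `Cc1ccc(OCC(=O)Nc2nc(-c3ccc(C)cc3)cs2)cc1` gives 45100 nM. Compound 4 `Cc1ccc(-c2csc(NC(=O)COc3ccc(Cl)cc3)n2)cc1` has not yet been measured.

Compound 2 arises from compound 1 by chloro in place of methyl on an aromatic carbon, and the step in this assay is a 1.1-fold higher number from compound 1 to compound 2 (0.06 log units; within the scatter). Compound 3 arises from compound 1 by 4-methylphenyl in place of 2-methylphenyl on an oxygen on a saturated carbon, and the step is a 1.2-fold lower number from compound 1 to compound 3 (0.09 log units; within the scatter). Compound 3 has the lowest of the three numbers, but each of its gaps to compound 1 and compound 2 is within the scatter, so no order among the three can be read from these values.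

Compound 4 arises from compound 3 by chloro in place of methyl on an aromatic carbon. The place of this change is the same, word for word, as for the change from compound 1 to compound 2, so it is the same change, now set on the core of compound 3 rather than the core of compound 1; those two cores differ as told by the change from compound 1 to compound 3 above.

Going by the values given here, with only one earlier instance to rest on, the expectation is that the step from compound 3 to compound 4 stays close to that seen from compound 1 to compound 2, that is, a step estimated at a 1.1-fold higher number from compound 3 to compound 4 (0.04 log units; within the scatter). Compound 4 is therefore expected to give about 50000 nM in this assay, estimated to fall between 25000 nM and 100000 nM.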

Compound 4, half-maximal inhibitory concentration: 42000 nM
For compound 4 the middle estimate is 1.2-fold (0.08 log units) above the measured one, within the range that was stated.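

In this assay chloro in place of methyl on an aromatic carbon gives a 1.1-fold lower number from compound 3 to compound 4 (0.03 log units; within the scatter), and the two instances of this change can be set side by side: the same change on two cores in this assay, a 1.1-fold higher number (0.06 log units; within the scatter) from compound 1 to compound 2 and a 1.1-fold lower number (0.03 log units; within the scatter) from compound 3 to compound 4, 1.2-fold (0.09 log units) apart, within the scatter of two such steps. On the cores of compound 1 and compound 3 the change therefore carries over with no difference that stands out from the scatter, and the wider replacement of 2-methylphenyl by 4-chlorophenyl on the ether oxygen also stays small, at a 1.3-fold lower number from compound 1 to compound 4 (0.12 log units; within the scatter). Going by these compounds alone, this shows only that the change leaves the number within the scatter on these two cores; neither instance is a step of any clear size, so the agreement does not show that a real effect would transfer from one core to another, and two instances establish no rule for the series.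

The compounds shown leave open whether a group of another kind on these aromatic rings, such as an amine, a carboxylic acid or a methoxy group, or a longer chain leading to the amide carbonyl, would move the number beyond the scatter. Going by these compounds, whether chloro in place of methyl keeps so small a step on any further core also stays open.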